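A few compounds are considered here, and "the series" means these few. Any claim that something is new, unique, unknown or untested is made for them only; others in the source may bear on it.

For the measured compounds named here, compound 3 `Fc1ccccc1-c1cn2ccnc2c(-c2ccc3ncn(C4CCCCC4)c3c2)n1` gives 5.77% in a functional assay on LOX IMVI cells (Homo sapiens) for inhibition, read by sulforhodamine B assay, with a stated time of 48 h, tested at 10 uM (on this read-out lower numbers stand for less inhibition and higher numbers for more inhibition at the one concentration tested (going by the name of the read-out)), which places it second highest of the three numbers so far. Its nearest neighbour is compound 1 `Fc1ccc(-c2cn3ccnc3c(-c3ccc4ncn(C5CCCCC5)c4c3)n2)cc1`, which gives 3.5% in this assay; the step of a number 2.3 percentage points higher from compound 1 to compound 3 (within the scatter) lies within the scatter. Furthest off is compound 2 `Clc1ccc(-c2cn3ccnc3c(-c3ccc4ncn(C5CCCCC5)c4c3)n2)cc1`, which gives 14.8% in this assay; the step of a number 9 percentage points lower from compound 2 to compound 3 (within the scatter) also lies within the scatter.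

Compound 4 `FC(F)(F)c1cccc(-c2cn3ccnc3c(-c3ccc4ncn(C5CCCCC5)c4c3)n2)c1` differs from compound 3 in one place: 3-(trifluoromethyl)phenyl in place of 2-fluorophenyl on an aromatic carbon.

Going by the values given here, only one measured step exceeds the scatter, the halogen swap a number 11.3 percentage points higher from compound 1 to compound 2 (beyond the scatter), a modest rise. Among the compounds with values here, no measured step exchanges a fluorophenyl for a trifluoromethylphenyl, so the present change has no direct precedent. All three measured numbers sit low, and on that basis a small rise or no step beyond the scatter is expected for this assay. Compound 4 is therefore estimated at 10%, within 0% to 25%, which would mean an expected step of a number 4.2 percentage points higher from compound 3 to compound 4 (within the scatter).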

Compound 4, a percentage reported as inhibition, at one concentration (the size of the read-out at that concentration, not a potency): 3.45%
Beside the measured number, compound 4's estimate is 6.6 percentage points above it, within the range that was stated.
By their numbers in this assay, from the lowest: compounds 4, 1, 3 and 2 (each within the scatter of the next, the first and the last beyond it).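

With 3-(trifluoromethyl)phenyl at this position of the shared core, the number in this assay does not separate from those of the fluorophenyl compounds: the steps are a number 2.3 percentage points lower from compound 3 to compound 4 (within the scatter) and a number 0.1 percentage points lower from compound 1 to compound 4 (within the scatter) in this series. The 4-chlorophenyl of compound 2 is set apart from compound 4 by a number 11.4 percentage points lower from compound 2 to compound 4 (beyond the scatter) in the same way as from compound 1, though compound 3 goes against a clean split, since its step to compound 2 stays within the scatter. Nothing measured here bears on why the numbers fall this way.

All four numbers are low at the one concentration tested. Still open, on these data alone, is whether an amine or a carboxylic acid on the phenyl ring, in place of halogen or trifluoromethyl, would move the number beyond the scatter.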